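This account rests on a few compounds, and the source may have more. Where it says the series, first, only, none or still open, it means among the compounds named here.

Of the compounds shown here, two of one shared core have been measured so far. Compound 1 `CCOc1cc(=O)n(CCCO)c2c1CC(CC=C(C)C)C(C)(C)C2` carries a plain hydroxypropyl chain on the ring nitrogen, and in a functional assay on PANC-1 cells (Homo sapiens) for inhibition, read by MTT assay, with a stated time of 24 h, tested at 10 uM (a higher number here means more inhibition at the concentration tested (going by the name of the read-out), a lower number less inhibition), compound 1 gives 16.6%. Compound 2 `CC(C)=CCC1Cc2c(OCCCNS(=O)(=O)c3ccc([N+](=O)[O-])cc3)cc(=O)n(CCCO)c2CC1(C)C` adds a longer chain ending in a sulfonamide, and in this assay compound 2 gives 17.3%. The two numbers sit within the usual scatter of each other, so compound 2 stands level with compound 1 rather than apart from it; neither compound reaches strong inhibition at the concentration tested.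

Compound 3 `CC(C)=CCC1Cc2c(OCCCNC(=O)c3ccco3)cc(=O)n(CCCO)c2CC1(C)C` keeps the core and the chain of compound 2 but changes the group on the amine nitrogen: (furan-2-yl)carbonyl in place of (4-nitrophenyl)sulfonyl on an amine nitrogen. For the measured compounds named here, no measured pair shows what such a swap does here, and the only comparison available, between compound 1 and compound 2, shows that a large change at this end of the chain left the number where it was. The step is therefore expected to be small, in no set direction, and no larger than the scatter, which is what a number 0.3 percentage points lower from compound 2 to compound 3 (within the scatter) means. For compound 3 the expected value is 17%, with a range from 5% to 32%.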

Compound 3, a percentage reported as inhibition, at one concentration (the size of the read-out at that concentration, not a potency): 4.3%
Compound 3: the middle estimate sits 12.7 percentage points above what was measured; the whole stated range lies above it.
By their numbers in this assay, from the lowest: compound 3; then compounds 1 and 2 (each within the scatter of the next).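

The group on the amine nitrogen at the end of this chain does affect the result in this assay: (furan-2-yl)carbonyl in place of (4-nitrophenyl)sulfonyl gives a number 13 percentage points lower from compound 2 to compound 3 (beyond the scatter), although the first two compounds gave no sign that this end of the molecule could shift the number. Measured against the short chain of compound 1, (((furan-2-yl)carbonyl)amino)methyl in place of hydrogen on a saturated chain carbon, two bonds along the chain from an oxygen on an aromatic ring, gives a number 12.3 percentage points lower from compound 1 to compound 3 (beyond the scatter), so the longer chain does not behave the same way with every end group: it stays level with compound 1 when it ends in the sulfonamide and drops away when it ends in the furan amide. Nothing available here bears on what lies behind this drop.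

This single swap changes the linking group and the ring together, so it cannot show which of the two matters. A (4-nitrophenyl)carbonyl or a (furan-2-yl)sulfonyl group on the same nitrogen would separate them, and a free amine there would show how the chain behaves with no acyl or sulfonyl group at all.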